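This account rests on a few compounds, and the source may have more. Where it says the series, first, only, none or still open, it means among the compounds named here.

Compound 2 `COc1ccccc1-n1cc(COC(=O)/C(C)=C/CC/C(C)=C/CC/C(C)=C/CC[C@@H]2[C@@]3(C)CCC(=O)C(C)(C)[C@H]3CC[C@@]2(C)O)nn1` is tested in an ADME assay on L132 cells (Homo sapiens) for cytotoxicity, read by MTT assay, with a stated time of 48 h; on this read-out lower numbers stand for stronger inhibition and higher numbers for weaker inhibition. Here compound 2 gives > 150000 nM, which is a limit of the assay rather than a number. Compound 1 `C/C(=C\CC/C(C)=C/CC[C@@H]1[C@@]2(C)CCC(=O)C(C)(C)[C@H]2CC[C@@]1(C)O)CC/C=C(\C)C(=O)OCc1cn(-c2ccc([N+](=O)[O-])cc2)nn1` shares the same core and carries 4-nitrophenyl instead on the aromatic nitrogen. In this assay compound 1 gives > 150000 nM, again a limit. The step that the two limits leave unreadable from compound 1 to compound 2 therefore cannot be read in size, since both values sit at the limit of > 150000 nM in this assay, at which 2 of the 2 values shown sit. Compound 3 `C/C(=C\CC/C(C)=C/CC[C@@H]1[C@@]2(C)CCC(=O)C(C)(C)[C@H]2CC[C@@]1(C)O)CC/C=C(\C)C(=O)OCc1cn(-c2ccc(C(C)(C)C)cc2)nn1` is not yet measured. It differs from compound 2 by 4-(tert-butyl)phenyl in place of 2-methoxyphenyl on an aromatic nitrogen. Among the measured compounds shown here, no measured step with a readable size bears on a change at this position, and the two values shown rest at the same limit, so no step beyond the scatter is expected. Compound 3 is expected to give 200000 nM in this assay, with a range from 100000 nM to 500000 nM. The expected step that the limit leaves unreadable from compound 2 to compound 3 is thus estimated to be essentially none.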

Compound 3, half-maximal inhibitory concentration: 65800 nM
Compound 3: middle estimate off by 3.0-fold (0.48 log units), on the high side, outside the stated range (below it).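

In this assay, among the compounds shown here, the group on the aromatic nitrogen does matter: swapping 2-methoxyphenyl for 4-(tert-butyl)phenyl brings an at least 2.2-fold lower number from compound 2 to compound 3 (0.35 log units; beyond the scatter) and gives the first readable number. Putting tert-butyl in place of nitro on an aromatic carbon brings an at least 2.2-fold lower number from compound 1 to compound 3 (0.35 log units; beyond the scatter) as well, so this position can shift the read-out, with the lower number meaning stronger cytotoxicity. Both sizes are floors and not full measurements, and the starting values are limits of the assay, not numbers: the limit of > 150000 nM in this assay, at which 2 of the 3 values shown sit.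

From the compounds shown here alone, how far compound 3 truly lies from compound 1 and compound 2 stays open, and a single readable value gives no trend across groups. Also open, going by these compounds, is how an amine or a carboxylic acid on the same phenyl ring, in place of tert-butyl, would read.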